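The compounds below may be only part of what the source reports. "The series", "measured", "known", "first", "only" and "open" are said of these compounds alone.

The series shares one core. In a functional assay on A-375 cells (Homo sapiens) for cytotoxicity, read by MTT assay, with a stated time of 72 h, tested at 3 uM (on this read-out higher numbers stand for more inhibition of growth at the one concentration tested and lower numbers for less inhibition of growth), compound 1 `Cc1ccnc(/C(N)=N/NC(=S)N2CCOCC2)c1` gives 66.6%. Compound 2 `Cc1ccnc(/C(N)=N/NC(=S)N2CCSCC2)c1` gives 67.2% in this assay, and compound 3 `N/C(=N\NC(=S)N1CCSCC1)c1ccccn1` gives 80% in this assay. Compound 2 thus stands second highest of the three numbers: its nearest neighbour is compound 1, with a number 0.6 percentage points higher from compound 1 to compound 2 (within the scatter), and its furthest is compound 3, with a number 12.8 percentage points higher from compound 2 to compound 3 (beyond the scatter).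

Compound 4 `Cc1ccnc(/C(N)=N/NC(=S)N2CCCCC2)c1` is not yet measured. It differs from compound 2 by piperidin-1-yl in place of thiomorpholin-4-yl on a thiocarbonyl carbon. Among the measured compounds shown here, of the measured steps only one bears on this change, the earlier exchange of the ring on the thiocarbonyl carbon, which from compound 1 to compound 2 gave a number 0.6 percentage points higher from compound 1 to compound 2 (within the scatter), within the scatter. The other step, a number 12.8 percentage points higher from compound 2 to compound 3 (beyond the scatter), concerns the aromatic carbon and says nothing about the ring on the thiocarbonyl carbon. For the measured compounds named here, the single relevant step therefore gives no ground to expect a step beyond the scatter in this assay in either direction. Compound 4 is accordingly estimated at 66%, with a range from 50% to 80%. The step this estimate implies, a number 1.2 percentage points lower from compound 2 to compound 4 (within the scatter), is expected to stay within the scatter.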

Compound 4, percent growth inhibition at one concentration: 69.5%
Beside the measured number, compound 4's estimate is 3.5 percentage points below it; measured number inside the range.
By their numbers in this assay, from the lowest: compounds 1, 2 and 4 (each within the scatter of the next); then compound 3.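

With piperidin-1-yl on the thiocarbonyl carbon, the ring carries neither the sulfur of thiomorpholin-4-yl nor the oxygen of morpholin-4-yl, and this assay still shows only a small move: a number 2.3 percentage points higher from compound 2 to compound 4 (within the scatter) and a number 2.9 percentage points higher from compound 1 to compound 4 (within the scatter). Earlier, the ring exchange at this place was known only from morpholin-4-yl and thiomorpholin-4-yl, whereas all three rings now stand within the scatter of one another on the methyl-bearing core, so this read-out at the one concentration tested does not tell them apart. No supporting measurement bears on why these exchanges leave the number level.

The compounds shown leave open whether this level holds for an open-chain dimethylamino group or a piperazin-1-yl ring on the thiocarbonyl carbon, since all three groups compared so far are six-membered rings. They also leave open whether the gain seen with hydrogen in place of methyl on the aromatic carbon, shown here only with thiomorpholin-4-yl, carries over to morpholin-4-yl and piperidin-1-yl.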